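This account rests on a few compounds, and the source may have more. Where it says the series, first, only, none or still open, it means among the compounds named here.

Measured so far in an assay on isolated protein for binding affinity to leukotriene B4 receptor 1 (Homo sapiens), tested at 1 uM; on this read-out lower numbers stand for less inhibition and higher numbers for more inhibition at the one concentration tested (going by the name of the read-out):
Compound 1 `C=CCc1cc(C(C)=O)c(O)cc1OCCCCCCCC#N` gives 52%.
Compound 2 `CCc1cc(C(C)=O)c(O)cc1OCCCC(C)(C)c1nnn[nH]1` gives 76%.
Compound 3 `CCCc1cc(C(C)=O)c(O)cc1OCCCCC(=O)O` gives 0%.

Compound 1 stands second of the three numbers: compound 2 sits higher, beyond the scatter, and compound 3 sits lower, beyond the scatter. Only the chain end and the small alkyl on the core vary, and the two gaps point in opposite directions, so no pattern is claimed across the three.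

Compound 4 `C=CCc1cc(C(C)=O)c(O)cc1OCCCCCC(=O)N(C)C` differs from compound 1 in one place: dimethylcarbamoyl in place of 2-cyanoethyl on a saturated chain carbon, five bonds along the chain from an oxygen on an aromatic ring. Going by the values given here, no comparable step between measured compounds is available, so the size of this step is open; a neutral group ends the chain in both, and a step within the scatter is expected, with a slight lean downward. Compound 4 is estimated at 45% in this assay, between 15% and 75%, meaning an expected step of a number 7 percentage points lower from compound 1 to compound 4 (within the scatter).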

Compound 4, a percentage reported as inhibition, at one concentration (the size of the read-out at that concentration, not a potency): 54%
Compound 4: the middle estimate sits 9 percentage points below what was measured; the measured number falls inside the stated range.
By their numbers in this assay, from the lowest: compound 3; then compounds 1 and 4 (each within the scatter of the next); then compound 2.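

In this assay, dimethylcarbamoyl in place of 2-cyanoethyl on this saturated chain carbon gives a small step (a number 2 percentage points higher from compound 1 to compound 4 (within the scatter)), so at this position the amide end and the nitrile end cannot be told apart. Going by these compounds alone, this is the first comparison that differs in one place, which the earlier compounds did not offer. No measured evidence explains why the two chain ends read alike.

Open, on these data alone, is whether an amine or a primary amide ending the chain of compound 1 would read the same. Also open, as far as these compounds go, is whether a longer chain carrying the dimethylcarbamoyl end would hold this level.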